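Opening a Ring Between Two Sulfurs on an Amide Chain

A few compounds are considered here, and "the series" means these few. Any claim that something is new, unique, unknown or untested is made for them only; others in the source may bear on it.

Going by the values given here, the three compounds measured so far share an amide whose chain ends in a sulfur-bearing group, while the aromatic part on the nitrogen differs. Compound 1, `O=C(CCCCC1CCSS1)Nc1ccc([N+](=O)[O-])c(C(F)(F)F)c1`, and compound 3, `O=C(CCCCC(S)CCS)Nc1ccc([N+](=O)[O-])c(C(F)(F)F)c1`, carry the same nitro- and trifluoromethyl-bearing core; compound 2, `O=C(CCCCC1CCSS1)Nc1cccc2ccccc12`, carries a different core, and the difference between the two cores is not broken down here.

All three were tested in a functional assay on NCI-H460 cells (Homo sapiens) for inhibition, read by MTT assay, with a stated time of 24 h, tested at 1 ug/mL; a higher number here means more inhibition of growth at the concentration tested, a lower number less inhibition of growth. Compound 1 gives 19.1%, compound 3 gives 6.29%, and compound 2 gives 4.15%. The change from compound 1 to compound 3 is a group of 5 heavy atoms (3 carbon, 2 sulfur; no ring) in place of a group of 5 heavy atoms (3 carbon, 2 sulfur; one five-membered non-aromatic ring with 2 hetero atoms), on a saturated chain carbon, four bonds along the chain from a carbonyl carbon, and it produced a step of a number 12.8 percentage points lower from compound 1 to compound 3 (beyond the scatter). The values of compound 2 and compound 3 lie close to each other.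

The unmeasured compound 4, `O=C(CCCCC(S)CCS)Nc1cccc2ccccc12`, stands to compound 2 as compound 3 stands to compound 1: the change is a group of 5 heavy atoms (3 carbon, 2 sulfur; no ring) in place of a group of 5 heavy atoms (3 carbon, 2 sulfur; one five-membered non-aromatic ring with 2 hetero atoms), on a saturated chain carbon, four bonds along the chain from a carbonyl carbon, the same change made at the same place. Compound 4 is expected to give about 1.5%, with a range from -8% to 11%. This expectation means a step of a number 2.7 percentage points lower from compound 2 to compound 4 (within the scatter). It rests on the measured step of a number 12.8 percentage points lower from compound 1 to compound 3 (beyond the scatter) and on the low starting point of compound 2 at 4.15%, which leaves little room for a further fall before the read-out reaches no growth inhibition at all.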

Compound 4, percent growth inhibition at one concentration: "not active" (no number reported)
No number was reported for compound 4; there is nothing to compare the estimate with.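

In this assay, going by these compounds alone, compound 4 is recorded as "not active" (no number reported) and so no step from compound 2 to compound 4 can be read. The compounds shown leave open whether replacing the ring with 1,3-disulfanylpropyl changes growth inhibition on the core of compound 2 as it does on the core of compound 1. Nothing measured here offers an explanation for this result.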